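A few compounds are considered here, and "the series" means these few. Any claim that something is new, unique, unknown or untested is made for them only; others in the source may bear on it.

Measured so far in a functional assay (trachea) with Cavia porcellus as the target; a higher number here means that more compound is needed for the effect, a lower number that less compound is needed:
- Compound 1 `CCCn1c(=O)n(C)c(=O)c2[nH]cnc21`: 1600 nM
- Compound 2 `CCCn1c(=O)n(C)c(=O)c2c1ncn2CCN(C)C`: > 100000 nM (a limit)

Compound 2 reads > 100000 nM in this assay, and this is a limit of the assay, not a number. Going by the values given here, the one measured step is an at least 62-fold higher number from compound 1 to compound 2 (1.79 log units; beyond the scatter), with 2-(dimethylamino)ethyl in place of hydrogen on an aromatic nitrogen.

Compound 3 `CCCn1c(=O)n(C)c(=O)c2c1ncn2CCO` keeps the chain but has hydroxy in place of dimethylamino on a saturated chain carbon, two bonds along the chain from an aromatic nitrogen.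

The measured step bears on this change only in part: it brought in the whole chain, whereas here the chain stays and only its end group changes. Among the compounds with values here, no step on the end group alone has been measured. Compound 1, at 1600 nM in this assay, therefore serves as the expected reference point for any recovery. A moderate move to a lower number is expected, estimated as an at least 2.5-fold lower number from compound 2 to compound 3 (0.39 log units; beyond the scatter), and the reading may again be only a limit. For compound 3 the estimate is 40000 nM, with an expected range from 8000 nM to 200000 nM in this assay.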

Compound 3, half-maximal effective concentration: 31800 nM
For compound 3 the middle estimate is 1.3-fold (0.10 log units) above the measured one, and the stated range covers the measured number.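

Changing only the end group of the chain gives an at least 3.1-fold lower number from compound 2 to compound 3 (0.49 log units; beyond the scatter) in this assay. This shows that the end group alone moves the reading, which the earlier step could not show because it brought in the chain and its end group together: the limit of > 100000 nM in this assay, at which 1 of the 3 values shown sits. Even with hydroxy at the end of the chain, the reading does not return to that of compound 1, since the chain still gives a 20-fold higher number from compound 1 to compound 3 (1.30 log units; beyond the scatter) and compound 1 stands at 1600 nM in this assay.

The compounds shown leave open how other groups at the end of the chain would read, such as a carboxylic acid or a primary amine, and how a longer chain carrying hydroxy would compare with 2-hydroxyethyl. They also leave open whether any chain on this aromatic nitrogen can come back to the reading of compound 1, or whether a small group such as methyl would already give a higher number than hydrogen does.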